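Replacing the ester arm on the aniline nitrogen with an acid

The compounds below may be only part of what the source reports. "The series", "measured", "known", "first", "only" and "open" are said of these compounds alone.

Measured compounds:
Compound 1, `COc1ccc(CS(=O)(=O)/C=C/c2c(F)cc(F)cc2F)cc1N`: 2000 nM
Compound 2, `COc1ccc(CS(=O)(=O)/C=C/c2cc(OC)c(OC)cc2OC)cc1N`: 250 nM
Compound 3, `COC(=O)C(C)(C)Nc1cc(CS(=O)(=O)/C=C/c2c(OC)cc(OC)cc2OC)ccc1OC`: 2500 nM

These three compounds were tested in a functional assay on DU-145 cells (Homo sapiens) for cytotoxicity, read by trypan blue exclusion, with a stated time of 96 h; on this read-out lower numbers stand for stronger inhibition and higher numbers for weaker inhibition. Compound 3, with its value of 2500 nM, has the highest number of the three. The gap to compound 1 lies within the scatter, so the two cannot be told apart; the gap to compound 2 lies beyond the scatter, and compound 2 clearly gives the lower number.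

Compound 4, `COc1cc(OC)c(/C=C/S(=O)(=O)Cc2ccc(OC)c(NC(C(=O)O)c3ccc(Br)cc3)c2)c(OC)c1`, is not yet measured. It differs from compound 3 in one place: (4-bromophenyl)(carboxy)methyl in place of 1-(methoxycarbonyl)-1-methylethyl on a nitrogen on an aromatic ring. The entering group is larger and carries a carboxylic acid and a bromine on its aromatic ring, while the leaving group carried an ester.

Among the measured compounds shown here, no measured pair shows what such a change does here. Given that compound 3 already gives 2500 nM, a modest step toward a higher number is expected, with the chance of none beyond the scatter. The expected step from compound 3 to compound 4 is a 1.6-fold higher number from compound 3 to compound 4 (0.20 log units; within the scatter). For compound 4 the expected value in this assay is 4000 nM, within a range from 1000 nM to 15000 nM.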

Compound 4, half-maximal inhibitory concentration: 300 nM
The estimate for compound 4 lay 13-fold (1.12 log units) above the measured number; the whole stated range lies above it.
By their numbers in this assay, from the lowest: compounds 2 and 4 (each within the scatter of the next); then compounds 1 and 3 (each within the scatter of the next).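

In this assay, placing (4-bromophenyl)(carboxy)methyl in place of 1-(methoxycarbonyl)-1-methylethyl on a nitrogen on an aromatic ring gives an 8.3-fold lower number from compound 3 to compound 4 (0.92 log units; beyond the scatter). Among the compounds shown here, the earlier compounds offered no single-place comparison, so this is the first sign that the group on this nitrogen can shift the number by more than the scatter. It also shows that this position accepts the larger entering group, which brings an aromatic ring, a bromine and a carboxylic acid, with a lower number as the result. Nothing shown here gives a reason for the step.

As far as these compounds go, the change alters several features at once, so the share of each remains open. A carboxymethyl group would test the acid without the aromatic ring, and a (carboxy)(phenyl)methyl group would test the role of the bromine.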